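Cyclobutyl ether on the aromatic oxygen of compound 3

The compounds below may be only part of what the source reports. "The series", "measured", "known", "first", "only" and "open" are said of these compounds alone.

Compound 3 `CCc1sc(CCc2cc(OCC3(C)CC3)cc(NCc3cc(Cl)cc(NC(=O)OC(C)C)c3)n2)nc1C` has the highest of the three numbers in an assay on cells for binding affinity to Neuropeptide Y receptor type 1 (Homo sapiens); on this read-out lower numbers stand for stronger inhibition and higher numbers for weaker inhibition; compound 3 gives 17 nM. Its nearest neighbour is compound 2 `CCc1sc(CCc2cc(OC(C)C)cc(NCc3cc(Cl)cc(NC(=O)OC(C)C)c3)n2)nc1C`, which gives 12 nM in this assay, a gap within the scatter. Compound 1 `CC/C=C\CCOc1cc(CCc2nc(C)c(CC)s2)nc(NCc2cc(Cl)cc(NC(=O)OC(C)C)c2)c1` gives 4.7 nM in this assay, and the steps of a 2.6-fold higher number from compound 1 to compound 2 (0.41 log units; beyond the scatter) and a 3.6-fold higher number from compound 1 to compound 3 (0.56 log units; beyond the scatter) are both beyond the scatter.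

Compound 4 `CCc1sc(CCc2cc(OC3CCC3)cc(NCc3cc(Cl)cc(NC(=O)OC(C)C)c3)n2)nc1C` differs from compound 3 in one place: cyclobutyl in place of (1-methylcyclopropyl)methyl on an oxygen on an aromatic ring. The step that bears most directly on this change is a 1.4-fold higher number from compound 2 to compound 3 (0.15 log units; within the scatter), an exchange of one small group for another on the same oxygen that stayed within the scatter. The larger steps from compound 1 involve its hex-3-en-1-yl group and do not apply here, since compound 4 keeps a small group on that oxygen. The change is therefore expected to give no step beyond the scatter in this assay, a 1.1-fold lower number from compound 3 to compound 4 (0.05 log units; within the scatter). Compound 4 is estimated at 15 nM in this assay, with a range of 7 nM to 35 nM.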

Compound 4, half-maximal inhibitory concentration: 11 nM
Beside the measured number, compound 4's estimate is 1.4-fold (0.13 log units) above it; low and high end bracket the measured number.
By their numbers in this assay, from the lowest: compound 1; then compounds 4, 2 and 3 (each within the scatter of the next).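

Cyclobutyl adds a four-membered ring to the small groups tried on this oxygen in this assay, and with a 1.5-fold lower number from compound 3 to compound 4 (0.19 log units; within the scatter) and a 1.1-fold lower number from compound 2 to compound 4 (0.04 log units; within the scatter), both within the scatter, it cannot be told apart from either the three-membered-ring group or open-chain isopropyl. Hex-3-en-1-yl now stands apart from all three small groups, with a 2.3-fold higher number from compound 1 to compound 4 (0.37 log units; beyond the scatter) beyond the scatter but modest, so compound 1 keeps the lowest number of the series. Nothing available accounts for this separation or for the lack of one among the small groups.

Going by these compounds, it remains open whether the length of the hex-3-en-1-yl chain or its double bond goes with the lower number, a question a saturated hexyl group on this oxygen would address. On these data alone, how an amine or a carboxylic acid at the end of such a chain would read in this assay also remains open.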